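Biaryl for propyl in an acylguanidine series

The source may report more compounds than this note shows. Statements on the series, on what has been measured and on what is new or still open speak of the compounds shown alone.

Three benzoylguanidines carrying a methylsulfonyl group have been measured in a functional assay for inhibition of sodium/hydrogen exchanger (Oryctolagus cuniculus); a lower number here means a stronger inhibitor, a higher number a weaker inhibitor. Compound 1 `CCc1cc(Br)c(S(C)(=O)=O)cc1C(=O)N=C(N)N` gives 41 nM. Compound 2 `CCCc1cc(C)c(C(=O)N=C(N)N)cc1S(C)(=O)=O` gives 5.7 nM, and compound 3 `Cc1c(C(=O)N=C(N)N)cc(S(C)(=O)=O)c(C)c1C` gives 55 nM. Compound 2 holds the lowest number of the three, and its gaps to compound 1 and to compound 3 both lie beyond the scatter, so it is the strongest inhibitor among the measured set. None of the three differs from another in one place only, so no single change has been isolated in these data.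

Compound 4 `Cc1cc(-c2ccc(Cl)cc2Cl)c(S(C)(=O)=O)cc1C(=O)N=C(N)N` is not yet measured. Relative to compound 2 the change is 2,4-dichlorophenyl in place of propyl on an aromatic carbon. For the measured compounds named here, no measured pair shows this kind of exchange, so the direction rests on expectation alone. A bulkier group at this position is expected to cost some potency; the step of a 3.5-fold higher number from compound 2 to compound 4 (0.55 log units; beyond the scatter) is estimated as a moderate rise, beyond the scatter but not large. Compound 4 is therefore expected to give about 20 nM, within a range from 5 nM to 80 nM.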

Compound 4, half-maximal inhibitory concentration: 42 nM
Compound 4: middle estimate off by 2.1-fold (0.32 log units), on the low side; measured number inside the range.
By their numbers in this assay, from the lowest: compound 2; then compounds 1, 4 and 3 (each within the scatter of the next).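

In this assay, the exchange of propyl for 2,4-dichlorophenyl gives a 7.4-fold higher number from compound 2 to compound 4 (0.87 log units; beyond the scatter), the first single change isolated in this series. The position, on an aromatic carbon ortho to a methylsulfonyl group, thus carries an aromatic ring with inhibition retained, but at a cost beyond the scatter. Nothing on hand speaks to the origin of this loss.

One exchange cannot separate the contribution of the ring from that of its two chlorine atoms, and a plain phenyl or a 4-chlorophenyl at this position would divide the step between them. Going by these compounds, whether size alone tracks the number also stays open: a butyl chain or a methoxy group here would test the trend on the non-aromatic side of propyl.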